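Swapping Bromo for Methoxy Ahead of Measurement

The source may report more compounds than this note shows. Statements on the series, on what has been measured and on what is new or still open speak of the compounds shown alone.

Compound 1 `O=C(O)c1ccc(CN2C(=O)S/C(=C\c3ccc(Br)cc3)C2=O)cc1` is the reference point of a small set tested in a functional assay on MCF7 cells (Homo sapiens) for cytotoxicity, read by MTT assay, with a stated time of 24 h (on this read-out lower numbers stand for stronger inhibition and higher numbers for weaker inhibition), where compound 1 gives 48000 nM. Within the data shown here, of the three numbers measured so far, compound 1 has the lowest, although compound 2 `O=C(O)c1ccc(CN2C(=O)S/C(=C\c3ccncc3)C2=O)cc1`, which in this assay gives 84000 nM, lies within the scatter of it; the step between them is a 1.8-fold higher number from compound 1 to compound 2 (0.24 log units; within the scatter). Compound 3 `O=C(O)c1ccc(CN2C(=O)S/C(=C\c3ccccc3)C2=O)cc1`, with 100000 nM in this assay, sits a little further up, and between the other two the step is a 1.2-fold higher number from compound 2 to compound 3 (0.08 log units; within the scatter).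

Compound 4 `COc1ccc(/C=C2\SC(=O)N(Cc3ccc(C(=O)O)cc3)C2=O)cc1` has not yet been measured. It differs from compound 1 by methoxy in place of bromo on an aromatic carbon. The step bearing most directly on this change is the one in which bromo left that same aromatic carbon with hydrogen in its place: a 2.1-fold higher number from compound 1 to compound 3 (0.32 log units; beyond the scatter), a modest rise. The ring swaps among compound 1, compound 2 and compound 3 all stayed within the scatter. Among the measured compounds shown here, no measured step shows methoxy entering at that position, so the expectation rests on the loss of bromo alone. Compound 4 is therefore expected to show a step of a 1.5-fold higher number from compound 1 to compound 4 (0.16 log units; within the scatter), which may well stay within the scatter. The estimate for compound 4 in this assay is 70000 nM, with a range from 30000 nM to 160000 nM.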

Compound 4, half-maximal inhibitory concentration: 48000 nM
Compound 4: the middle estimate sits 1.5-fold (0.16 log units) above what was measured; low and high end bracket the measured number.
By their numbers in this assay, from the lowest: compounds 1, 4, 2 and 3 (each within the scatter of the next, the first and the last beyond it).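

In this assay, methoxy and bromo cannot be told apart at this aromatic carbon (no change at the digits printed from compound 1 to compound 4 (within the scatter)), so the position now tolerates a second group with no visible loss relative to compound 1. Methoxy in place of hydrogen gives a modest step beyond the scatter (a 2.1-fold lower number from compound 3 to compound 4 (0.32 log units; beyond the scatter)), and bromo in compound 1 stands apart from compound 3 by a step of the same printed size (a 2.1-fold higher number from compound 1 to compound 3 (0.32 log units; beyond the scatter)), so the hydrogen compound is now separated from two different groups at this carbon, not one. The 4-methoxyphenyl of compound 4 stays within the scatter of the pyridin-4-yl of compound 2 (a 1.8-fold lower number from compound 2 to compound 4 (0.24 log units; within the scatter)), so this comparison separates neither group from the other.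

No supporting measurement is available to explain why bromo and methoxy give the same reading here. As far as these compounds go, it remains open whether a different group at this carbon, such as an amine, a carboxylic acid or a longer chain like butoxy, would match compound 1 and compound 4 or move away from them.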